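A few compounds are considered here, and "the series" means these few. Any claim that something is new, unique, unknown or untested is made for them only; others in the source may bear on it.

Compound 1 `C/C=C/C(=O)Nc1c(C(O)(C(F)(F)F)C(F)(F)F)ccc2ccccc12`, compound 2 `O=C(NCCCCCCCl)Nc1c(C(O)(C(F)(F)F)C(F)(F)F)ccc2ccccc12` and compound 3 `O=C(Nc1ccc(Cl)cc1)Nc1c(C(O)(C(F)(F)F)C(F)(F)F)ccc2ccccc12` share a core and differ only in the group on the carbonyl carbon. In an assay on LtK cells with ATP-sensitive inward rectifier potassium channel 11 (Homo sapiens) as the target (a higher number here means that more compound is needed for the effect, a lower number that less compound is needed), compound 1 gives 72 nM, compound 2 gives 4840 nM and compound 3 gives 276 nM. Compound 3 stands second highest of the three: the step of a 3.8-fold higher number from compound 1 to compound 3 (0.58 log units; beyond the scatter) is modest, while the step of an 18-fold lower number from compound 2 to compound 3 (1.24 log units; beyond the scatter) is large, and the step of a 67-fold higher number from compound 1 to compound 2 (1.83 log units; beyond the scatter) sets the widest span among the measured compounds.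

Compound 4 `O=C(Nc1c(C(O)(C(F)(F)F)C(F)(F)F)ccc2ccccc12)c1ccc(Br)cc1` is the next member. The change from compound 3 is 4-bromophenyl in place of (4-chlorophenyl)amino on a carbonyl carbon. Both measured steps into compound 3 bear on it, since each swaps the group on the carbonyl carbon. The step of an 18-fold lower number from compound 2 to compound 3 (1.24 log units; beyond the scatter) shows that a six-membered aromatic ring of carbon only at this position is favoured over a 6-chlorohexyl chain, and the step of a 3.8-fold higher number from compound 1 to compound 3 (0.58 log units; beyond the scatter) shows that a group bound to the carbonyl carbon without the amino link gave a lower number than the (4-chlorophenyl)amino group. An aromatic ring bound directly to the carbonyl carbon is therefore expected to give a modest lowering of the number in this assay, a 2.5-fold lower number from compound 3 to compound 4 (0.40 log units; beyond the scatter). Compound 4 is expected to give 110 nM, within the range 35 nM to 400 nM.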

Compound 4, half-maximal effective concentration: 47 nM
Compound 4: middle estimate off by 2.3-fold (0.37 log units), on the high side; the measured number falls inside the stated range.
By their numbers in this assay, from the lowest: compounds 4 and 1 (each within the scatter of the next); then compound 3; then compound 2.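

The step of a 5.9-fold lower number from compound 3 to compound 4 (0.77 log units; beyond the scatter) in this assay shows that an aromatic ring need not reach the carbonyl carbon through an amino link: 4-bromophenyl, with no hydrogen-bond donor, gives a lower number here than (4-chlorophenyl)amino, which has one. Among the compounds shown here, until now the only ring-bearing compound stood beyond the scatter from compound 1, but the step of a 1.5-fold lower number from compound 1 to compound 4 (0.19 log units; within the scatter) places 4-bromophenyl level with prop-1-en-1-yl in this assay, while the step of a 100-fold lower number from compound 2 to compound 4 (2.01 log units; beyond the scatter) is now the widest span. None of the available data explain why the number moves with these groups.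

Compound 4 both loses the amino link and carries bromine where compound 3 carries chlorine, so these two changes remain unseparated, and a 4-chlorophenyl or plain phenyl group bound directly to the carbonyl carbon would be needed to tell them apart. As far as these compounds go, it also remains open how a methoxy group or a carboxylic acid on that ring, or a saturated cyclohexyl ring in its place, would affect the number.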